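From 3-nitrophenyl to pyridin-2-yl on the shared core

A few compounds are considered here, and "the series" means these few. Any claim that something is new, unique, unknown or untested is made for them only; others in the source may bear on it.

Compound 1 `COc1ccc(C(=O)/C=C/c2ccc(F)cc2)c2c1C=CC(C)(C)O2`: > 10000 nM (a limit)
Compound 2 `COc1ccc(C(=O)/C=C/c2ccc(N(C)C)cc2)c2c1C=CC(C)(C)O2`: 2750 nM
Compound 3 `COc1ccc(C(=O)/C=C/c2cccc([N+](=O)[O-])c2)c2c1C=CC(C)(C)O2`: 9720 nM

In a functional assay on SK-OV-3 cells (Homo sapiens) for antiproliferative activity, read by MTT assay, with a stated time of 24 h (a higher number here means a weaker inhibitor, a lower number a stronger inhibitor), compound 3 gives 9720 nM, the higher of the two actual numbers. Compound 1 gives only a limit, > 10000 nM. The one measured gap between actual numbers is a 3.5-fold higher number from compound 2 to compound 3 (0.55 log units; beyond the scatter).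

Compound 4 `COc1ccc(C(=O)/C=C/c2ccccn2)c2c1C=CC(C)(C)O2` has not yet been measured. It carries pyridin-2-yl in place of 3-nitrophenyl on a double-bonded chain carbon bound to a double-bonded chain carbon.

The three measured steps all concern the aromatic group at this place. One is the gap already given, and the second is an at least 3.6-fold lower number from compound 1 to compound 2 (0.56 log units; beyond the scatter). The third is an at least 1.0-fold lower number from compound 1 to compound 3 (0.01 log units; that floor lies within the scatter). Going by the values given here, both steps that involve compound 2 are beyond the scatter, but neither tells the direction of a change to pyridin-2-yl, since no measured compound carries a ring with a hetero atom here. In this assay, no clear step is therefore expected, although a modest fall in the number remains possible. The expected change is a 1.6-fold lower number from compound 3 to compound 4 (0.21 log units; within the scatter). Compound 4 could also report only a limit. The estimate for compound 4 is 6000 nM, with an expected range from 2500 nM to 10000 nM.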

Compound 4, half-maximal inhibitory concentration: 8390 nM
Compound 4: the middle estimate sits 1.4-fold (0.15 log units) below what was measured; the measured number falls inside the stated range.
By their numbers in this assay, from the lowest: compound 2; then compounds 4 and 3 (each within the scatter of the next). At a limit, above all of these: compound 1.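

In this assay, pyridin-2-yl, the only ring with a hetero atom shown at this place, in place of 3-nitrophenyl gives a 1.2-fold lower number from compound 3 to compound 4 (0.06 log units; within the scatter), so these two groups cannot be told apart here, even though the entering group has fewer heavy atoms. Set against 4-(dimethylamino)phenyl, the same change gives a 3.1-fold higher number from compound 2 to compound 4 (0.48 log units; beyond the scatter), which leaves compound 2 as the one compound clearly set apart from both compound 3 and compound 4, and shows that a nitrogen within the ring does not reproduce what the dimethylamino group on the phenyl ring gives. The step of an at least 1.1-fold lower number from compound 1 to compound 4 (0.07 log units; that floor lies within the scatter) cannot be read, because its starting value is a limit rather than a number: the limit of > 10000 nM in this assay, at which 1 of the 4 values shown sits.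

The compounds shown leave open whether another amine on the phenyl ring, as in 4-aminophenyl or 4-(pyrrolidin-1-yl)phenyl, would keep the lower number of compound 2. They also leave open whether pyridin-3-yl or pyridin-4-yl would differ from pyridin-2-yl at this place.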